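A few compounds are considered here, and "the series" means these few. Any claim that something is new, unique, unknown or untested is made for them only; others in the source may bear on it.

Measured compounds:

compound 1, `C=C1C(=O)[C@]23C[C@@]1(O)CC[C@H]2c1ccc(OS(=O)(=O)c2ccc(C)cc2)c(C)c1[C@@H]3Cn1cc(-c2ccc(Cl)cc2)nn1` — in a functional assay on HL-60 cells (Homo sapiens) for cytotoxicity, read by MTT assay, with a stated time of 4 days (on this read-out lower numbers stand for stronger inhibition and higher numbers for weaker inhibition), compound 1 gives 1260 nM

compound 2, `C=C1C(=O)[C@]23C[C@@]1(O)CC[C@H]2c1ccc(O)c(C)c1[C@@H]3Cn1cc(-c2ccc(Cl)cc2)nn1` — in this assay compound 2 gives 690 nM

Among these two numbers compound 1 has the highest; its nearest neighbour is compound 2, and the step from compound 1 to compound 2 reads a 1.8-fold lower number from compound 1 to compound 2 (0.26 log units; within the scatter), so the two values cannot be told apart. That step concerns the oxygen on the aromatic ring of the shared core, where hydrogen replaces the (4-methylphenyl)sulfonyl group.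

Compound 3, `C=C1C(=O)[C@]23C[C@@]1(O)CC[C@H]2c1ccc(OS(=O)(=O)c2ccc(C)cc2)c(C)c1[C@@H]3Cn1cc(-c2ccc(OC)cc2)nn1`, is a different matter. It keeps the (4-methylphenyl)sulfonyl group of compound 1 and changes only the ring hanging from the triazole: methoxy in place of chloro on an aromatic carbon. Within the data shown here, no measured pair shows this exchange, so the only measured step gives no direct guidance on it. Among the measured compounds shown here, since the one step seen so far stayed within the scatter, no step beyond the scatter is expected here either, and the estimated step from compound 1 to compound 3 is no change at the digits printed from compound 1 to compound 3 (within the scatter). Compound 3 is therefore expected to give about 1260 nM in this assay, with a range from 450 nM to 3500 nM.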

Compound 3, half-maximal inhibitory concentration: 1020 nM
Beside the measured number, compound 3's estimate is 1.2-fold (0.09 log units) above it; the measured number falls inside the stated range.
By their numbers in this assay, from the lowest: compounds 2, 3 and 1 (each within the scatter of the next).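

In this assay, swapping chloro for methoxy, which turns the 4-chlorophenyl group into a 4-methoxyphenyl group, gives a 1.2-fold lower number from compound 1 to compound 3 (0.09 log units; within the scatter), so the two compounds cannot be told apart. Among these compounds, the earlier pair only tested the oxygen on the aromatic ring of the shared core, whereas this step is the first reading at a second place: an aromatic carbon para to a large group. There, with the (4-methylphenyl)sulfonyl group kept, replacing one chlorine atom with a carbon and an oxygen, which adds one hydrogen-bond acceptor, does not move the number beyond the scatter, and no measurement at hand helps to interpret this result.

From the compounds shown here alone, it remains open whether the same exchange would read alike on compound 2, which carries a hydrogen instead of the (4-methylphenyl)sulfonyl group on that oxygen. Going by these compounds, it is also open whether a different group at this carbon, such as an amine, a carboxylic acid or a longer chain like butoxy, would shift the number beyond the scatter.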